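The source may report more compounds than this note shows. Statements on the series, on what has been measured and on what is new or still open speak of the compounds shown alone.

Going by the values given here, in an ADME assay on the whole organism (Rattus norvegicus) for pharmacokinetics, using cassette dosing, at a dose of 1 mg/kg by the oral route (on this read-out higher numbers stand for higher oral bioavailability and lower numbers for lower oral bioavailability), compound 3 (`C[C@@H](Cn1c(=O)[nH]/c(=N\c2ccc(Oc3cccc(F)n3)cc2)n(Cc2ccc(Cl)cc2)c1=O)C(=O)O`) gives 60%, the lowest number so far, with compound 1 (`Cc1ccc(Cn2c(=O)n(C[C@H](C)C(=O)O)c(=O)[nH]/c2=N\c2ccc(OC(C)C)c(Cl)c2)cc1`) at 73.1% and compound 2 (`C[C@@H](Cn1c(=O)[nH]/c(=N\c2ccc(Oc3ccc(F)cn3)cc2)n(Cc2ccc(Cl)cc2)c1=O)C(=O)O`) at 82.4%. Compound 4 (`C[C@@H](Cn1c(=O)[nH]/c(=N\c2ccc(OC3CCC3)cc2)n(Cc2ccc(Cl)cc2)c1=O)C(=O)O`) brings this change: cyclobutyl in place of 6-fluoropyridin-2-yl on an oxygen on an aromatic ring. Among the compounds with values here, the only measured step at that oxygen is a number 22.4 percentage points lower from compound 2 to compound 3 (beyond the scatter); it keeps an aromatic ring there, so it bears only loosely. The closest guide is compound 1 at 73.1%, with a non-aromatic group on that oxygen, although it differs elsewhere too. A modest rise in this assay is therefore expected, and the estimated step is a number 12 percentage points higher from compound 3 to compound 4 (beyond the scatter). Compound 4 is estimated at 72%, within a range of 50% to 90%.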

Compound 4, oral bioavailability: 54.3%
Compound 4: middle estimate off by 17.7 percentage points, on the high side, within the range that was stated.
By their numbers in this assay, from the lowest: compounds 4 and 3 (each within the scatter of the next); then compounds 1 and 2 (each within the scatter of the next).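

In this assay, the step of a number 5.7 percentage points lower from compound 3 to compound 4 (within the scatter) shows that cyclobutyl and 6-fluoropyridin-2-yl on this oxygen cannot be told apart, so a non-aromatic ring in place of the aromatic one brings no separation here. The step of a number 28.1 percentage points lower from compound 2 to compound 4 (beyond the scatter) leaves compound 2, with 5-fluoropyridin-2-yl, standing apart from both other groups at this position. No measurement bears on the reason for either step. Open, from the compounds shown here alone, is how an amine or a longer ether chain on this oxygen would read, and whether 5-fluoropyridin-2-yl keeps its standing on the core of compound 1.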